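The source may report more compounds than this note shows. Statements on the series, on what has been measured and on what is new or still open speak of the compounds shown alone.

Measured so far:
- compound 2, `CC(C)(C)OC(=O)N1CCC(Oc2ncnc3c2CCN3c2ccc(S(C)(=O)=O)cc2F)CC1`: 20 nM
- compound 1, `CC(C)OC(=O)N1CCC(Oc2ncnc3c2CCN3c2ccc(-c3cccn3C)cc2F)CC1`: 158 nM

In a functional assay on CHO-K1 cells for agonist activity at Glucose-dependent insulinotropic receptor (Homo sapiens), read by a luciferase reporter, with a stated time of 5 h (a higher number here means that more compound is needed for the effect, a lower number that less compound is needed), compound 2 gives 20 nM and stands at the lowest of the two numbers; the nearest, compound 1, gives 158 nM, a gap that lies beyond the scatter. Compound 1 and compound 2 differ in more than one place, so no single step can be read from that pair.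

Compound 3, `CCOC(=O)N1CCC(Oc2ncnc3c2CCN3c2ccc(S(C)(=O)=O)cc2F)CC1`, is not yet measured. It differs from compound 2 by ethyl in place of tert-butyl on an oxygen next to a carbonyl group. Among the measured compounds shown here, no measured pair isolates a change at that oxygen, so the size of the step is uncertain; a moderate rise in the number, towards less potency, is expected rather than a fall, but a result within the scatter cannot be ruled out.

For compound 3 the expected value in this assay is 50 nM, range 15 nM to 200 nM, which means an estimated step of a 2.5-fold higher number from compound 2 to compound 3 (0.40 log units; beyond the scatter).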

Compound 3, half-maximal effective concentration: 251 nM
The estimate for compound 3 lay 5.0-fold (0.70 log units) below the measured number; measured number outside the range, above it.
By their numbers in this assay, from the lowest: compound 2; then compounds 1 and 3 (each within the scatter of the next).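

In this assay, among the compounds shown here, the change of ethyl in place of tert-butyl, on an oxygen next to a carbonyl group, gives a 13-fold higher number from compound 2 to compound 3 (1.10 log units; beyond the scatter) and is the first step that can be read from a single place. This position therefore responds strongly to the group it carries: with the rest of compound 2 held fixed, removing carbon from the tert-butyl group costs much of the potency. The data shown offer no measurement that explains the size of this step.

On these data alone, only tert-butyl and ethyl can be compared at this oxygen, so it remains open whether a cyclobutyl group or a longer chain such as n-butyl would sit near compound 2 or near compound 3. As far as these compounds go, whether the step keeps its size alongside other groups on the shared core also remains open, as compound 1 differs from both compound 2 and compound 3 in more than one place.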